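The source may hold more compounds than are shown below. What is called first, only, known or untested is meant among the compounds shown, and "the series" means these compounds.

Measured so far:
Compound 1, `CCCCN(CC)c1cc(C)nc2c1NC(=O)CN2c1ccc(C)cc1C`: 3.9 nM
Compound 2, `CCCCN(CC)c1cc(C)nc2c1NC(=O)CN2c1ccc(I)cc1C`: 3.4 nM

Compound 1 and compound 2 share one core and differ only in a single substituent on the aryl ring that sits on the ring nitrogen. In an assay on HEK-293T cells for displacement of a labelled ligand from corticotropin-releasing factor receptor 1 (Homo sapiens), read by scintillation counting, with a stated time of 2 h (a lower number here means a stronger inhibitor, a higher number a weaker inhibitor), compound 1 gives 3.9 nM and compound 2 gives 3.4 nM. The step of a 1.1-fold lower number from compound 1 to compound 2 (0.06 log units; within the scatter) is within the scatter, so the two compounds cannot be placed in order; compound 2 merely has the lower of the two numbers.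

Compound 3, `CCCCN(CC)c1cc(C)nc2c1NC(=O)CN2c1ccc(Br)cc1CC`, has not been measured. Its change from compound 2 is 4-bromo-2-ethylphenyl in place of 4-iodo-2-methylphenyl on a nitrogen on an aromatic ring in a ring: bromine takes the place of iodine, and an ethyl takes the place of the methyl on the same aryl ring. Among the compounds with values here, the only measured step that bears on it is a 1.1-fold lower number from compound 1 to compound 2 (0.06 log units; within the scatter), which shows that exchanging methyl for iodo at that position left the number within the scatter. Within the data shown here, no measured pair speaks to the change from methyl to ethyl. The expectation for compound 3 in this assay is therefore a step of a 1.1-fold higher number from compound 2 to compound 3 (0.02 log units; within the scatter), no clear direction beyond the scatter, and compound 3 is estimated at 3.6 nM, within 1.5 nM to 9 nM.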

Compound 3, inhibition constant: 2.5 nM
Beside the measured number, compound 3's estimate is 1.4-fold (0.16 log units) above it; measured number inside the range.
By their numbers in this assay, from the lowest: compounds 3, 2 and 1 (each within the scatter of the next).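

In this assay, placing 4-bromo-2-ethylphenyl on the ring nitrogen gives a 1.4-fold lower number from compound 2 to compound 3 (0.13 log units; within the scatter) and a 1.6-fold lower number from compound 1 to compound 3 (0.19 log units; within the scatter), so both steps stay within the scatter and the three compounds cannot be placed in order. Compound 1 and compound 2 had shown only that iodo and methyl could be exchanged on this aryl ring without a readable step, whereas compound 3 extends that finding to an aryl group with an ethyl and a bromine, with the number still in the same range. Nothing at hand offers an explanation for this result.

Bromine and ethyl enter together in both steps, so the compounds shown leave open what each change does alone, and whether an ethyl with iodine or a methyl with bromine would give a similar number. They also leave open whether this position would keep its number with a longer chain such as propyl in place of the ethyl, or with an amine or a carboxylic acid in place of the bromine.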